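A few compounds are considered here, and "the series" means these few. Any claim that something is new, unique, unknown or untested is made for them only; others in the source may bear on it.

Three measured compounds share a core and differ in the group carried on one ring and in where the hydroxyl sits on the other. Compound 1 `Nc1ccccc1/C=C/c1cccc(O)c1` carries an amino group, and in a functional assay on HT-29 cells (Homo sapiens) for inhibition, read by MTT assay, with a stated time of 2 days (on this read-out lower numbers stand for stronger inhibition and higher numbers for weaker inhibition), compound 1 gives 30 ug/mL. Compound 3 `COc1ccccc1/C=C/c1cccc(O)c1` differs from compound 1 in one place, (methoxy in place of amino on an aromatic carbon). In this assay compound 3 gives 17 ug/mL, a step of a 1.8-fold lower number from compound 1 to compound 3 (0.25 log units; within the scatter). Compound 2 `Nc1cccc(/C=C/c2ccc(O)cc2)c1` has the same atoms as compound 1 joined differently; the difference between the two cores is not broken down here. In this assay compound 2 gives 51 ug/mL, the highest of the three numbers, within the scatter of compound 1 but beyond the scatter relative to compound 3.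

Compound 4 `COc1cccc(/C=C/c2ccc(O)cc2)c1` has not yet been measured. It stands to compound 2 as compound 3 stands to compound 1, through (methoxy in place of amino on an aromatic carbon). The two changes are of the same kind rather than the same: in compound 3 the methoxy is ortho to a group of 9 heavy atoms, whereas in compound 4 it is meta to a group of 9 heavy atoms. A step of similar size is expected, a 1.7-fold lower number from compound 2 to compound 4 (0.23 log units; within the scatter). For the measured compounds named here, this expectation rests on the single measured example of the change, a 1.8-fold lower number from compound 1 to compound 3 (0.25 log units; within the scatter), and on the value of compound 2, 51 ug/mL. In this assay compound 4 is expected to give about 30 ug/mL, with a likely range from 12 ug/mL to 75 ug/mL.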

Compound 4, half-maximal inhibitory concentration: 26 ug/mL
Compound 4: middle estimate off by 1.2-fold (0.06 log units), on the high side; measured number inside the range.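

In this assay, methoxy in place of amino on an aromatic carbon, meta to a group of 9 heavy atoms, gives a 2.0-fold lower number from compound 2 to compound 4 (0.29 log units; within the scatter). Set beside the earlier example, the change carries from one core to the other with no difference in size that can be told apart from the scatter: the same change on two cores in this assay, a 1.8-fold lower number (0.25 log units; within the scatter) from compound 1 to compound 3 and a 2.0-fold lower number (0.29 log units; within the scatter) from compound 2 to compound 4, 1.1-fold (0.05 log units) apart, within the scatter of two such steps. This shows agreement between two small steps on two cores, each step within the scatter by itself, so it does not establish that methoxy and amino differ in this read-out on either core, and it says nothing about cores beyond these two.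

The compounds shown leave open whether an ethoxy group, a dimethylamino group or a fluorine atom in the place of the amino group would give a step of similar size, and whether a larger step would appear with any of them. They also leave open whether the same agreement would hold on a core that carries a carboxylic acid or a longer chain in the place of the hydroxyl, where the two steps seen here offer no guide.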